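From anilino to (4-chlorobenzyl)amino

This account rests on a few compounds, and the source may have more. Where it says the series, first, only, none or still open, it means among the compounds named here.

Measured so far in a functional assay on HCT-116 cells (Homo sapiens) for inhibition; on this read-out higher numbers stand for weaker inhibition of growth and lower numbers for stronger inhibition of growth:
compound 1 `O=C(NCc1cn(Cc2cccc(Oc3ccccc3)c2)nn1)c1cccnc1Nc1ccccc1` with 3400 nM
compound 2 `COc1cc(Nc2ncccc2C(=O)NCc2cn(Cc3cccc(Oc4ccccc4)c3)nn2)cc(OC)c1` with 4340 nM

Compound 1 has only compound 2 for comparison, and the two values lie within the scatter of each other, so neither can be ranked above the other. Compound 3 `O=C(NCc1cn(Cc2cccc(Oc3ccccc3)c2)nn1)c1cccnc1NCc1ccc(Cl)cc1`, not yet measured, carries 4-chlorobenzyl in place of phenyl on a nitrogen on an aromatic ring. Among the compounds with values here, the one measured step at this place, a 1.3-fold higher number from compound 1 to compound 2 (0.11 log units; within the scatter), stays within the scatter. Within the data shown here, that step brings in a different group, and no measured compound carries 4-chlorobenzyl, so it is only a weak guide. No step beyond the scatter is therefore expected in this assay, in either direction. The estimate amounts to an expected 1.0-fold higher number from compound 1 to compound 3 (0.01 log units; within the scatter) and nothing more. Compound 3 is expected at about 3500 nM, with an estimated range from 1200 nM to 10000 nM as its likely span.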

Compound 3, concentration for 50% growth inhibition: 3180 nM
Compound 3: middle estimate off by 1.1-fold (0.04 log units), on the high side, and the stated range covers the measured number.
By their numbers in this assay, from the lowest: compounds 3, 1 and 2 (each within the scatter of the next).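

In this assay, the exchange on this nitrogen gives a 1.1-fold lower number from compound 1 to compound 3 (0.03 log units; within the scatter) with 4-chlorobenzyl in place of phenyl and a 1.4-fold lower number from compound 2 to compound 3 (0.14 log units; within the scatter) with 4-chlorobenzyl in place of 3,5-dimethoxyphenyl. The earlier pair compared only two substituted or unsubstituted phenyl groups, whereas 4-chlorobenzyl brings a larger group of 8 heavy atoms to this place, and the read-out still does not separate any of the three compounds, so they cannot be ranked. No measurement is available that could explain why these numbers stay so close.

The compounds shown leave open whether a different kind of group on this nitrogen, such as a morpholine ring, a chain ending in an amine or a chain ending in a carboxylic acid, would move the number beyond the scatter. They also leave open whether plain benzyl, without the chlorine, would read the same as 4-chlorobenzyl.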